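From pyridin-3-yl to pyrimidin-2-yl: expected solubility

The source may hold more compounds than are shown below. What is called first, only, known or untested is meant among the compounds shown, and "the series" means these compounds.

For the measured compounds named here, compound 3 `Cc1cc(NCc2cccnc2)n2nc(C)c(-c3ccccc3)c2n1` is the one compound here with a true number: in a physicochemical assay for solubility, read by HPLC, using the shake flask method, measured as kinetic solubility, with a stated time of 2 h, at pH 7.4 (a higher number here means a more soluble compound, a lower number a less soluble compound), compound 3 gives 110000 nM. Compound 1 `Cc1cc(NCc2ccccn2)n2nc(C)c(-c3ccc(F)cc3)c2n1` in this assay gives < 5000 nM, which is a limit of the assay rather than a number. Compound 2 `Cc1cc(NCc2ccccn2)n2ncc(-c3ccc(F)cc3)c2n1` in this assay likewise gives < 5000 nM, again a limit. The step that the two limits leave unreadable from compound 1 to compound 2 cannot be sized because both of its ends sit at the limit of < 5000 nM in this assay, at which 2 of the 3 values shown sit.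

Compound 4 `Cc1cc(NCc2ncccn2)n2nc(C)c(-c3ccccc3)c2n1` differs from compound 3 by pyrimidin-2-yl in place of pyridin-3-yl on a saturated chain carbon bound to a nitrogen on an aromatic ring. Going by the values given here, no measured step makes this change; the single measured step concerns a different change and is unreadable, so it offers no guidance on direction or size. With nothing pointing either way, the expected step from compound 3 to compound 4 is no change at the digits printed from compound 3 to compound 4 (within the scatter), that is, none beyond the usual scatter. Compound 4 is therefore estimated at 110000 nM in this assay. For compound 4 the expected range runs from 40000 nM to 300000 nM.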

Compound 4, solubility: 37900 nM
Beside the measured number, compound 4's estimate is 2.9-fold (0.46 log units) above it; the whole stated range lies above it.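

For the compounds shown here, the only earlier step between compounds cannot be read, so this is the first change with a readable size in this assay. Putting pyrimidin-2-yl in place of pyridin-3-yl on a saturated chain carbon bound to a nitrogen on an aromatic ring gives a 2.9-fold lower number from compound 3 to compound 4 (0.46 log units; beyond the scatter), so the read-out responds to which of these two six-membered aromatic rings sits at this place. Nothing measured here explains why the number falls.

As far as these compounds go, how a plain phenyl ring or a morpholine at this place would compare with these two rings stays open. Also open, from the compounds shown here alone, is whether the same change would give a step of similar size on a compound with other groups on the shared core.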